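The source may hold more compounds than are shown below. What is called first, only, known or untested is meant among the compounds shown, and "the series" means these compounds.

Working notes on the series. Among the compounds with values here, compound 1 `O=[N+]([O-])c1ccc(CN2CCC(n3cc(CC(OCc4cc(-c5ccc(Br)cc5)no4)c4ccc(Br)cc4)nn3)CC2)cc1` is the first member measured in a functional assay on HCT-116 cells (Homo sapiens) for cytotoxicity, with a stated time of 48 h; a lower number here means a stronger inhibitor, a higher number a weaker inhibitor. In this assay compound 1 returns only the limit > 25000 nM, which is a limit of the assay and not a number. Compound 2 `O=[N+]([O-])c1ccc(CN2CCC(n3cc(CC(OCc4cc(-c5cccc(Br)c5)no4)c4ccc(Br)cc4)nn3)CC2)cc1` is the second member. In this assay compound 2 likewise returns only the limit > 25000 nM, again a limit and not a number. The step that the two limits leave unreadable from compound 1 to compound 2 links the two; its size cannot be read because the limit of > 25000 nM in this assay, at which 2 of the 2 values shown sit, places both ends at the limit. Compound 2 therefore stands at the upper edge of what the assay reports, with no number of its own and one further value beside it that is also a limit.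

Compound 3 `O=[N+]([O-])c1ccc(CN2CCC(n3cc(CC(OCc4cc(-c5cccc(F)c5)no4)c4ccc(Br)cc4)nn3)CC2)cc1` is the next member; it differs from compound 2 by fluoro in place of bromo on an aromatic carbon. Within the data shown here, no measured step bears on this exchange; the only step is itself unreadable in size. The expectation for compound 3 rests on the measured members sitting at the limit (the limit of > 25000 nM in this assay, at which 2 of the 2 values shown sit). Compound 3 is expected to remain near that limit, an estimated step that the limit leaves unreadable from compound 2 to compound 3. Compound 3 is estimated at 30000 nM, in the range 8000 nM to 100000 nM.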

Compound 3, half-maximal inhibitory concentration: 6000 nM
For compound 3 the middle estimate is 5.0-fold (0.70 log units) above the measured one; the whole stated range lies above it.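

In this assay, within the data shown here, the position on this six-membered aromatic ring of carbon only proves responsive: fluoro in place of bromo gives an at least 4.1-fold lower number from compound 2 to compound 3 (0.61 log units; beyond the scatter) and provides the first readable step. Set against compound 1, the 3-fluorophenyl group in place of 4-bromophenyl gives an at least 4.1-fold lower number from compound 1 to compound 3 (0.61 log units; beyond the scatter), so among these three compounds a number within the range of the assay appears only with fluoro. Both steps carry only a minimum size, and the step between the two bromo compounds cannot be read, because compound 1 and compound 2 each rest at a value that is a limit and not a number: the limit of > 25000 nM in this assay, at which 2 of the 3 values shown sit.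

On these data alone, it remains open whether another group at this place, such as methoxy, an amine or a carboxylic acid, would give a lower or a higher number than fluoro does in compound 3. As far as these compounds go, the second bromo group of the shared core is the same in all three compounds, so it also remains open how fluoro or a nitrile there would read.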